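The source may hold more compounds than are shown below. What is called first, only, known or untested is meant among the compounds shown, and "the series" means these compounds.

Values in an ADME assay for permeability, using PAMPA, with a stated time of 4 h, at pH 7.4; a lower number here means that the compound crosses the layer more slowly, a higher number that the compound crosses the layer faster:
compound 1 `NCCCCN(C[C@@H]1Cc2ncccc2CN1)[C@H]1CCCc2cccnc21`: 7 nm/s
compound 2 `CN(C[C@@H]1Cc2ncccc2CN1)[C@H]1CCCc2cccnc21`: 1000 nm/s
compound 3 `NC/C=C\CN(C[C@H]1Cc2ncccc2CN1)[C@H]1CCCc2cccnc21`: 68 nm/s

Of these three, compound 3 stands second highest, with 68 nm/s beyond the scatter of both others. Compound 4 `NC(=O)NCCCCN(C[C@H]1Cc2ncccc2CN1)[C@H]1CCCc2cccnc21` differs from compound 3 by 3-ureidopropyl in place of 3-aminoprop-1-en-1-yl on a saturated chain carbon bound to an amine nitrogen. Among the compounds with values here, one measured step bears on this: a 140-fold higher number from compound 1 to compound 2 (2.15 log units; beyond the scatter) is large, but there a hydrogen replaces the 3-aminopropyl outright. Within the data shown here, compound 4 keeps a chain at that place, and no measured compound carries the ureido group. No step beyond the scatter is therefore expected in this assay, in either direction. The estimated change is a 1.3-fold higher number from compound 3 to compound 4 (0.12 log units; within the scatter). The expected value for compound 4 is 90 nm/s, within an estimated range of 20 nm/s to 350 nm/s.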

Compound 4, apparent permeability: 2 nm/s
The estimate for compound 4 lay 45-fold (1.65 log units) above the measured number; measured number below the stated range.
By their numbers in this assay, from the lowest: compound 4; then compound 1; then compound 3; then compound 2.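

In this assay, replacing 3-aminoprop-1-en-1-yl with 3-ureidopropyl gives a 34-fold lower number from compound 3 to compound 4 (1.53 log units; beyond the scatter) even though a chain stays at this place. The earlier compounds shown here showed a large step only where hydrogen replaced the chain outright, whereas this result shows that exchanging one chain for another can also produce a large step. No evidence on the cause of this step is at hand. The exchange alters the chain and its end group at once, and the compounds shown cannot separate the two. Going by these compounds, how a carboxylic acid or a simple amide at the chain end would read remains open.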